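Moving the chlorine on the aryl ring of compound 3

The source may report more compounds than this note shows. Statements on the series, on what has been measured and on what is new or still open speak of the compounds shown alone.

Measured compounds:
compound 1 `COc1cccc(/C=N/c2c(C)n(C)n(-c3ccccc3)c2=O)c1`: 155000000 nM
compound 2 `Cc1c(/N=C/c2cccc([N+](=O)[O-])c2)c(=O)n(-c2ccccc2)n1C`: 741000000 nM
compound 3 `Cc1c(/N=C/c2ccc(Cl)cc2)c(=O)n(-c2ccccc2)n1C`: 309000000 nM

In a functional assay on HT-29 cells (Homo sapiens) for cytotoxicity, read by MTT assay, with a stated time of 72 h (on this read-out higher numbers stand for weaker inhibition and lower numbers for stronger inhibition), compound 3 gives 309000000 nM, the second highest of the three numbers. Its nearest neighbour is compound 1, and a 2.0-fold higher number from compound 1 to compound 3 (0.30 log units; within the scatter). Compound 2, in this assay, gives 741000000 nM, a higher number than that of compound 3. Compound 4 `Cc1c(/N=C/c2cccc(Cl)c2)c(=O)n(-c2ccccc2)n1C` is not yet measured; it differs from compound 3 only in that (3-chlorophenyl in place of 4-chlorophenyl on a carbon with a double bond to nitrogen). Within the data shown here, no measured step changes the position of a group on this ring while keeping the group itself, so nothing bears directly on it. Among the measured compounds shown here, the only step touching this ring that keeps the shared core, a 2.0-fold higher number from compound 1 to compound 3 (0.30 log units; within the scatter), stays within the scatter, and a 4.8-fold higher number from compound 1 to compound 2 (0.68 log units; beyond the scatter) is a modest change of substituent rather than of position. The account therefore expects no step beyond the scatter: compound 4 is estimated at 300000000 nM in this assay, with a range from 100000000 nM to 900000000 nM, which would mean a 1.0-fold lower number from compound 3 to compound 4 (0.01 log units; within the scatter).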

Compound 4, half-maximal inhibitory concentration: 269000000 nM
Compound 4: middle estimate off by 1.1-fold (0.05 log units), on the high side; low and high end bracket the measured number.
By their numbers in this assay, from the lowest: compounds 1, 4 and 3 (each within the scatter of the next); then compound 2.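

In this assay, among these compounds, this is the first step that changes only the position of a group on this ring, and a 1.1-fold lower number from compound 3 to compound 4 (0.06 log units; within the scatter) leaves 3-chlorophenyl and 4-chlorophenyl indistinguishable. Among the compounds shown here, with the new compound, the nature of the group can also be read against chloro: a 2.8-fold lower number from compound 2 to compound 4 (0.44 log units; beyond the scatter) with chloro in place of nitro, whereas a 1.7-fold higher number from compound 1 to compound 4 (0.24 log units; within the scatter) with chloro in place of methoxy, so only the step from nitro lies beyond the scatter. Nothing available accounts for either result.

On these data alone, whether moving nitro or methoxy would likewise leave the number within the scatter remains open. So does whether an amine or a carboxylic acid on this ring would give a number outside the span of these compounds.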